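This account rests on a few compounds, and the source may have more. Where it says the series, first, only, none or still open, it means among the compounds named here.

Measured in a physicochemical assay for lipophilicity, using the shake flask method, at pH 7.4; a higher number here means a more lipophilic compound, a lower number a more polar compound:
- compound 1 `Cc1ccccc1CNC(=O)c1nc(-c2ccc(F)cc2)n(CC[C@@H](O)C[C@@H](O)CC(=O)O)c1C1CC1`: 0.44
- compound 2 `O=C(O)C[C@H](O)C[C@H](O)CCn1c(-c2ccc(F)cc2)nc(C(=O)NCc2ccccc2F)c1C1CC1`: 0.08
- compound 3 `COc1ccc(CNC(=O)c2nc(-c3ccc(F)cc3)n(CC[C@@H](O)C[C@@H](O)CC(=O)O)c2C2CC2)cc1`: 0.02

Compound 3 shares the lower part of this range with one other compound: the series shows a number 0.06 log units lower from compound 2 to compound 3 (within the scatter), against a number 0.42 log units lower from compound 1 to compound 3 (beyond the scatter).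

Compound 4 `COc1ccccc1CNC(=O)c1nc(-c2ccc(F)cc2)n(CC[C@@H](O)C[C@@H](O)CC(=O)O)c1C1CC1` has the same atoms as compound 3, joined differently: 2-methoxyphenyl in place of 4-methoxyphenyl on a saturated chain carbon bound to an amide-type nitrogen. Here 2-methoxyphenyl stands in place of 4-methoxyphenyl on a saturated chain carbon bound to an amide-type nitrogen.

Going by the values given here, no measured step makes this change alone, so the evidence is indirect. The closest steps both end in the 4-methoxyphenyl of compound 3. Starting from 2-fluorophenyl gives a number 0.06 log units lower from compound 2 to compound 3 (within the scatter), and starting from 2-methylphenyl gives a number 0.42 log units lower from compound 1 to compound 3 (beyond the scatter). A third step, a number 0.36 log units lower from compound 1 to compound 2 (beyond the scatter), shows that the two groups bearing a substituent at the 2-position do not give the same number, so the group entering in compound 4 cannot be read from either one.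

Taken together, these steps point to a small rise rather than a fall, with no shift beyond the scatter expected. The expected change is a number 0.18 log units higher from compound 3 to compound 4 (within the scatter). For compound 4 the estimated value is 0.2, with an expected range from -0.15 to 0.55.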

Compound 4, distribution coefficient: 0.16
Beside the measured number, compound 4's estimate is 0.04 log units above it, within the range that was stated.
By their numbers in this assay, from the lowest: compounds 3, 2, 4 and 1 (each within the scatter of the next, the first and the last beyond it).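

In this assay, going by these compounds alone, the pair of compound 3 and compound 4 gives the first direct reading of 2-methoxyphenyl in place of 4-methoxyphenyl on a saturated chain carbon bound to an amide-type nitrogen (a number 0.14 log units higher from compound 3 to compound 4 (within the scatter)), and the two isomers are not separated at this position. Methoxy in place of fluoro (a number 0.08 log units higher from compound 2 to compound 4 (within the scatter)) and methoxy in place of methyl (a number 0.28 log units lower from compound 1 to compound 4 (within the scatter)) are also both within the scatter, so compound 4 is not separated from any of the other three compounds, even though compound 1 remains separated from compound 2 (a number 0.36 log units lower from compound 1 to compound 2 (beyond the scatter)) and from compound 3 (a number 0.42 log units lower from compound 1 to compound 3 (beyond the scatter)). No measurement available here accounts for any of these steps.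

As far as these compounds go, it remains open whether an amine or a carboxylic acid in place of the methoxy on the aromatic carbon would give a step beyond the scatter in this assay. A longer chain in place of the saturated chain carbon bound to an amide-type nitrogen is equally unresolved, as is whether the isomer pair would stay unseparated with that chain in place.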